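The source may report more compounds than this note shows. Statements on the series, on what has been measured and on what is new or still open speak of the compounds shown alone.

In an assay on isolated protein for inhibition of Rho-associated protein kinase 1 (Homo sapiens), read by radiometric assay and 33P incorporation, with a stated time of 40 min, in the presence of a further agent that is not named here (on this read-out higher numbers stand for weaker inhibition and lower numbers for stronger inhibition), compound 1 `COc1cccc(Cn2cnc3sc(-c4ccncc4)cc3c2=O)c1` gives 45 nM. Compound 2 `COc1cccc(Cn2cnc3sc(-c4cccnc4)cc3c2=O)c1` reaches only > 10000 nM in this assay, which is a limit of the assay and not a number. Compound 3 `COc1cccc(Cn2cnc3sc(-c4ccnc(C)c4)cc3c2=O)c1` gives 2520 nM in this assay, the highest of the two numbers shown, with compound 1 the nearest value below it. Compound 4 `COc1cccc(Cn2cnc3sc(-c4ccnc(OC)c4)cc3c2=O)c1` is not yet measured and differs from compound 3 in one place: methoxy in place of methyl on an aromatic carbon.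

The measured step that bears most on this change is a 56-fold higher number from compound 1 to compound 3 (1.75 log units; beyond the scatter), which placed a group on the same aromatic carbon next to the ring nitrogen. The step of an at least 3.9-fold lower number from compound 2 to compound 3 (0.59 log units; beyond the scatter) joins a change of ring attachment to that same methyl and is bounded by the limit (the limit of > 10000 nM in this assay, at which 1 of the 3 values shown sits), so it says less. Since a methoxy now stands where the methyl stood, compound 4 is expected in this assay to remain in the weak region of compound 3 or move higher, estimated at 4000 nM, within 1500 nM to 12000 nM. This amounts to an expected step of a 1.6-fold higher number from compound 3 to compound 4 (0.20 log units; within the scatter).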

Compound 4, half-maximal inhibitory concentration: > 10000 nM
Compound 4 was reported as a limit; the forecaster's own chance of this, stated with the estimate: 20%; middle value at least 2.5-fold (0.39 log units) away from the limit.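

In this assay, the position next to the ring nitrogen turns out to respond not only to the presence of a group but also to which group it carries: methoxy in place of methyl gives an at least 3.9-fold higher number from compound 3 to compound 4 (0.59 log units; beyond the scatter). Set against the unsubstituted pyridin-4-yl, the same position with methoxy shows an at least 220-fold higher number from compound 1 to compound 4 (2.34 log units; beyond the scatter), so both groups tried here stand far from the value of compound 1, and methoxy stands further. Compound 4 gives > 10000 nM, which is a limit of the assay and not a number, and the step that joins it to compound 2 cannot be read: the limit of > 10000 nM in this assay, at which 2 of the 4 values shown sit.

Going by these compounds, how far past this limit compound 4 lies remains open. So does whether a fluorine or an amine at this position would stay nearer to compound 1 than methyl does.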